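One chlorine in place of two on an amide nitrogen

A few compounds are considered here, and "the series" means these few. Any claim that something is new, unique, unknown or untested is made for them only; others in the source may bear on it.

Of the compounds shown here, three have been measured in an assay on isolated protein for inhibition of Farnesyl pyrophosphate synthase (Homo sapiens); a lower number here means a stronger inhibitor, a higher number a weaker inhibitor. Compound 1 `O=C(Nc1ccc(N2CCCCC2)cc1)C1=C(O)C(CCc2ccccc2)NC1=O` gives > 50000 nM, which is a limit of the assay and not a number. Compound 2 `O=C(Nc1ccc(Oc2ccccc2)cc1)C1=C(O)CC(Cc2ccccc2)NC1=O` likewise gives > 50000 nM, again a limit. Compound 3 `O=C(Nc1cc(Cl)cc(Cl)c1)C1=C(O)C(c2ccccc2)OC1=O` also gives > 50000 nM, a limit, so compound 3 stands where the other two stand: at the edge of what this assay can report, with no number of its own. Within the data shown here, the whole set sits on (the limit of > 50000 nM in this assay, at which 3 of the 3 values shown sit), and no step between measured compounds can be drawn from it.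

Compound 4 `O=C(Nc1ccc(Cl)cc1)C1=C(O)C(c2ccccc2)OC1=O` differs from compound 3 in one place, (4-chlorophenyl in place of 3,5-dichlorophenyl on an amide-type nitrogen). Among the measured compounds shown here, because compound 3 shows only > 50000 nM, no measured step tells what such a change does here; the author expects no step beyond the scatter, and the expected step that the limit leaves unreadable from compound 3 to compound 4 is essentially flat. For compound 4 the estimate is 80000 nM, within 25000 nM to 300000 nM, with the most likely outcome being another limit rather than a number.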

Compound 4, half-maximal inhibitory concentration: > 50000 nM
Compound 4 gave a limit, no number (the forecaster's own chance of this, stated with the estimate: 85%); the middle value is on the limit's open side.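

No step can be read from compound 3 to compound 4, since each gives a limit of the assay and not a number: the limit of > 50000 nM in this assay, at which 4 of the 4 values shown sit.

The compounds shown leave open whether 4-chlorophenyl in place of 3,5-dichlorophenyl changes inhibition at all, and which structure would give a readable number.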